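Amide substituent: isopropyl to methylpyrrolidinylmethyl

The source may report more compounds than this note shows. Statements on the series, on what has been measured and on what is new or still open speak of the compounds shown alone.

Compound 3 `CC(C)NC(=O)c1cc(-c2ccc(NS(=O)(=O)c3cccc(Cl)c3Cl)cc2)nc2[nH]ncc12` gives 68 nM in an assay for inhibition of serine/threonine-protein kinase Sgk1 (Homo sapiens), with stated times of 30 min and 60 min, in the presence of a further agent that is not named here (on this read-out higher numbers stand for weaker inhibition and lower numbers for stronger inhibition), the highest of the numbers in hand. Compound 2 `CC(C)N1CC[C@H](NC(=O)c2cc(-c3ccc(NS(=O)(=O)c4cccc(Cl)c4Cl)cc3)nc3[nH]ncc23)C1` gives 4 nM in this assay, the nearest value, and the step of a 17-fold higher number from compound 2 to compound 3 (1.23 log units; beyond the scatter) is large. Compound 1 `CN1CCC(NC(=O)c2cc(-c3ccc(NS(=O)(=O)c4cccc(Cl)c4Cl)cc3)nc3[nH]ncc23)C1` sits in this assay at the limit < 1 nM, which is a limit and not a number (the limit of < 1 nM in this assay, at which 1 of the 3 values shown sits). The step of an at least 68-fold higher number from compound 1 to compound 3 (1.83 log units; beyond the scatter) is large, and the step of an at least 4.0-fold higher number from compound 1 to compound 2 (0.60 log units; beyond the scatter) is at least modest, so every change away from the 1-methylpyrrolidin-3-yl group on the amide-type nitrogen seen so far has raised the number.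

Compound 4 `CN1CCC(CNC(=O)c2cc(-c3ccc(NS(=O)(=O)c4cccc(Cl)c4Cl)cc3)nc3[nH]ncc23)C1` differs from compound 3 in one place: (1-methylpyrrolidin-3-yl)methyl in place of isopropyl on an amide-type nitrogen. The entering group carries the same ring as compound 1, joined through one further carbon. The two steps that bear on this change are the large one from compound 1 to compound 3 and the large one from compound 2 to compound 3, both running toward weaker inhibition as the ring is removed. Reinstating a ring of this kind is therefore expected to give a large step toward stronger inhibition, a 34-fold lower number from compound 3 to compound 4 (1.53 log units; beyond the scatter). Compound 4 is estimated at 2 nM in this assay, with a range from 0.5 nM to 10 nM, and a value at the limit cannot be excluded.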

Compound 4, half-maximal inhibitory concentration: 14 nM
Compound 4: middle estimate off by 7.0-fold (0.85 log units), on the low side, and the stated range ends below it.
By their numbers in this assay, from the lowest: compound 2; then compound 4; then compound 3. At a limit, below all of these: compound 1.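

In this assay the (1-methylpyrrolidin-3-yl)methyl group improves on isopropyl at the amide-type nitrogen, but only in part, with a 4.9-fold lower number from compound 3 to compound 4 (0.69 log units; beyond the scatter) being modest, so carrying the ring on this nitrogen does not in itself give the full gain seen with the directly attached rings. The earlier compounds shown here compared only directly attached rings with isopropyl, whereas here the (1-methylpyrrolidin-3-yl)methyl group falls short of both, with a 3.5-fold higher number from compound 2 to compound 4 (0.54 log units; beyond the scatter) modest and an at least 14-fold higher number from compound 1 to compound 4 (1.14 log units; beyond the scatter) large, which shows that the way the ring is joined to this nitrogen matters as well as its presence. The value of compound 1 in this comparison is a limit and not a number: the limit of < 1 nM in this assay, at which 1 of the 4 values shown sits.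

The compounds shown do not separate the contribution of the ring carbons from that of the ring nitrogen, which a cyclopentyl group or an open-chain amine such as 2-(dimethylamino)ethyl on the same nitrogen would address. Also open, as far as these compounds go, is how a pyrrolidin-3-yl group with no substituent on its nitrogen, or the opposite stereoisomer of the ring in compound 2, would compare.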